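Swapping sulfamoyl for dimethylamino on a pyrimidine-anilino scaffold

The source may report more compounds than this note shows. Statements on the series, on what has been measured and on what is new or still open speak of the compounds shown alone.

Measured compounds:
compound 1, `CN(C)c1cccc(Nc2nccc(-c3cccs3)n2)c1`, 2400 nM
compound 2, `NS(=O)(=O)c1cccc(Nc2nccc(-c3ccncc3)n2)c1`, 500 nM

The series is followed in a functional assay for inhibition, with Homo sapiens as the target; on this read-out lower numbers stand for stronger inhibition and higher numbers for weaker inhibition. Of the compounds shown here, two have numbers so far. Compound 2 gives 500 nM, the lower of the two numbers, and its nearest neighbour, compound 1, stands at 2400 nM, a gap beyond the usual scatter. Compound 1 also carries a dimethylamino group, though it differs from compound 2 in more than one place, so its number alone cannot be traced to any single change.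

Compound 3, `CN(C)c1cccc(Nc2nccc(-c3ccncc3)n2)c1`, is not yet measured. It departs from compound 2 by one change: dimethylamino in place of sulfamoyl on an aromatic carbon. For the measured compounds named here, no measured pair shows this exact change on its own, so the size of the step is not known from the data. Going by the values given here, the only guide is that compound 1, the other dimethylamino-bearing compound, gives 2400 nM, a higher number than compound 2 at 500 nM. On that basis compound 3 is expected to show a higher number than compound 2, a step of a 3.0-fold higher number from compound 2 to compound 3 (0.48 log units; beyond the scatter), weaker inhibition beyond the scatter. The estimate for compound 3 is 1500 nM, in the range 400 nM to 6000 nM.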

Compound 3, half-maximal inhibitory concentration: 3700 nM
Estimate against measurement, compound 3: 2.5-fold (0.39 log units) below, and the stated range covers the measured number.
By their numbers in this assay, from the lowest: compound 2; then compounds 1 and 3 (each within the scatter of the next).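

In this assay, the exchange of sulfamoyl for dimethylamino on this aromatic carbon can now be read on its own, with the rest of the structure unchanged, and it gives a 7.4-fold higher number from compound 2 to compound 3 (0.87 log units; beyond the scatter) as a modest step towards weaker inhibition. This shows that the group at this position matters with pyridin-4-yl present, which the earlier pair could not show because its two compounds differ in more than one place. With dimethylamino held in place, pyridin-4-yl in place of thiophen-2-yl gives a 1.5-fold higher number from compound 1 to compound 3 (0.19 log units; within the scatter) and so does not separate the two compounds, while the data offer no measured explanation for either step.

The compounds shown leave open whether the step belongs to sulfamoyl in particular or would also appear with a methylsulfonyl group, a carboxamide or a carboxylic acid on the same aromatic carbon. They also leave open whether sulfamoyl would give a step of similar size alongside thiophen-2-yl, as it appears here only with pyridin-4-yl.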